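The compounds below may be only part of what the source reports. "The series", "measured", "known", "first", "only" and "open" are said of these compounds alone.

Working notes on the series.

The series shares one core, with a fatty acyl amide of varying length. Compound 1 `CCCCCCCCCCCC(=O)Nc1nnc(S[C@@H]2O[C@H](COC(C)=O)[C@H](OC(C)=O)[C@H](OC(C)=O)[C@H]2OC(C)=O)s1` carries the longest chain and the fully acetylated sugar; in a functional assay on SK-OV-3 cells (Homo sapiens) for cytotoxicity, read by MTT assay, with a stated time of 24 h (a lower number here means a stronger inhibitor, a higher number a weaker inhibitor), compound 1 is reported as "not active" (no number reported), with no single number. Compound 2 `CCCCCCCCCC(=O)Nc1nnc(S[C@@H]2O[C@H](CO)[C@H](O)[C@H](O)[C@H]2O)s1` has the free sugar and a shorter chain; in this assay compound 2 is likewise reported as "not active" (no number reported), again without a number. Going by the values given here, compound 3 `CCCCCCCC(=O)Nc1nnc(S[C@@H]2O[C@H](CO)[C@H](O)[C@H](O)[C@H]2O)s1`, shorter still, is the only member with a measured value: in this assay compound 3 gives 56000 nM. So compound 2 stands among the entries for which no number is given, while the only numbered entry in the series is a weak one.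

Compound 4 `CCCCCC(=O)Nc1nnc(S[C@@H]2O[C@H](CO)[C@H](O)[C@H](O)[C@H]2O)s1` has not been measured. It differs from compound 2 by hydrogen in place of butyl on a saturated chain carbon, five bonds along the chain from a carbonyl carbon. Among the compounds with values here, no step between measured compounds exists for comparison; the only signal is that the shorter-chain compound 3 yields a number where compound 2 does not. A modest gain toward measurable, weak cytotoxicity is expected, with a real chance that no number is reported. For compound 4 in this assay the estimate is 70000 nM, in the range 25000 nM to 200000 nM.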

Compound 4, half-maximal inhibitory concentration: "not active" (no number reported)
Nothing numeric was reported for compound 4, and the estimate cannot be compared.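

Compound 2 and compound 4 both stand without a number, so no step can be read between them. The compounds shown leave open how far the change from butyl to hydrogen moves cytotoxicity, if at all. Nothing shown offers an explanation for either result.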